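Nitro for Amino: One Change in the Series

The compounds below may be only part of what the source reports. "The series", "measured", "known", "first", "only" and "open" are said of these compounds alone.

Measured compounds in a functional assay on MDA-MB-468 cells (Homo sapiens) for cytotoxicity, read by MTT assay, with a stated time of 72 h; on this read-out higher numbers stand for weaker inhibition of growth and lower numbers for stronger inhibition of growth:
compound 1 `COc1ccc(CS(=O)(=O)/C=C/c2ccc(OC)c(OC)c2OC)cc1N` — 3480 nM
compound 2 `COc1ccc(CS(=O)(=O)/C=C/c2c(OC)cccc2OC)cc1N` — 60 nM
compound 3 `COc1cc(OC)c(NC(=O)CS(=O)(=O)Cc2ccc(OC)c([N+](=O)[O-])c2)c(OC)c1` — > 30000 nM

Of the two numbers, compound 1 gives the higher and compound 2 the lower, a gap beyond the usual scatter. Compound 3 sits at the limit of > 30000 nM in this assay, at which 1 of the 3 values shown sits, a limit and not a number. Compound 4 `COc1ccc(CS(=O)(=O)/C=C/c2ccc(OC)c(OC)c2OC)cc1[N+](=O)[O-]` differs from compound 1 in one place: nitro in place of amino on an aromatic carbon. Among the measured compounds shown here, no measured pair shares this change, so the size of the step rests on expectation alone. Compound 3 carries a nitro group on a different core, so its limit weighs little here. Compound 4 is expected in this assay at 8000 nM, between 2000 nM and 30000 nM. The expected step is a 2.3-fold higher number from compound 1 to compound 4 (0.36 log units; beyond the scatter), toward weaker growth inhibition, with a fair chance of a limit only.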

Compound 4, concentration for 50% growth inhibition: 21900 nM
The estimate for compound 4 lay 2.7-fold (0.44 log units) below the measured number, and the stated range covers the measured number.
By their numbers in this assay, from the lowest: compound 2; then compound 1; then compound 4. At a limit, above all of these: compound 3.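

On the core of compound 1, at the aromatic carbon ortho to a methoxy group and meta to a large group, nitro in place of amino weakens growth inhibition, with a 6.3-fold higher number from compound 1 to compound 4 (0.80 log units; beyond the scatter) in this assay as the step. Compound 4 still gives a number and not a limit, so growth inhibition on this core survives the change. Nothing at hand bears on the cause of this step.

As far as these compounds go, whether a hydroxyl or an acetamide at this position would read closer to amino or to nitro remains open. So does the size of the same change on the core of compound 2.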